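From Carboxy to Methoxymethyl on a Shared Core

The source may hold more compounds than are shown below. What is called first, only, known or untested is meant among the compounds shown, and "the series" means these compounds.

- compound 1 `COC(=O)c1c(C)coc1-c1ccc2c(c1OC)CCCC2(C)C`: 27.1 uM
- compound 2 `COc1c(-c2occ(C)c2C(=O)O)ccc2c1CCCC2(C)C`: 25.5 uM

These two compounds were tested in a functional assay on SK-BR-3 cells (Homo sapiens) for cytotoxicity, read by sulforhodamine B assay, with a stated time of 3 days; on this read-out lower numbers stand for an effect already at smaller amounts and higher numbers for an effect only at larger amounts of compound. There, compound 2 gives 25.5 uM and compound 1 gives 27.1 uM, and the two values lie within the scatter of each other. The account now turns to compound 3 `COCc1c(C)coc1-c1ccc2c(c1OC)CCCC2(C)C`, which has not yet been measured. It carries methoxymethyl in place of carboxy on an aromatic carbon, with the rest of the structure shared with compound 2 (methoxymethyl in place of carboxy on an aromatic carbon).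

Going by the values given here, only one measured step bears on this change. It is a 1.1-fold lower number from compound 1 to compound 2 (0.03 log units; within the scatter), which replaces hydrogen with methyl in reverse at the oxygen of the same group and stays within the scatter. Among the compounds with values here, no measured compound carries methoxymethyl, so the new group itself has not been tested, and the evidence for this expectation is thin. On that single step, no move beyond the scatter is expected in this assay. The expected step is a 1.2-fold lower number from compound 2 to compound 3 (0.06 log units; within the scatter), which would remain within the scatter. For compound 3 the estimated value is 22 uM, with an expected range of 9 uM to 50 uM.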

Compound 3, concentration for half-maximal effect: 18.5 uM
Beside the measured number, compound 3's estimate is 1.2-fold (0.08 log units) above it; the measured number falls inside the stated range.
By their numbers in this assay, from the lowest: compounds 3, 2 and 1 (each within the scatter of the next).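

Compounds 1 and 2 differ only at the oxygen of a group that keeps its carbonyl on this aromatic carbon of the five-membered aromatic ring, whereas compound 3 has no carbonyl there and also lacks the hydrogen-bond donor of carboxy. In this assay, methoxymethyl in place of carboxy gives a 1.4-fold lower number from compound 2 to compound 3 (0.14 log units; within the scatter), and methoxymethyl in place of methoxycarbonyl gives a 1.5-fold lower number from compound 1 to compound 3 (0.17 log units; within the scatter). Across these three compounds, then, the carbonyl at this position is not needed to keep the value within the scatter, though no measurement shown says why the values stay together.

The compounds shown leave open whether any group at this position can move the number beyond the scatter, since all three values lie within it. An amine, an amide or a longer ether chain on this aromatic carbon would test that, and the shared core, including the methyl group on the neighbouring ring atom named in the comparison, stays the same throughout.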